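This account rests on a few compounds, and the source may have more. Where it says the series, first, only, none or still open, it means among the compounds named here.

Measured compounds:
compound 1, `C#Cc1c(C)nc(N)nc1NCCCC`, 4900 nM;
compound 2, `CCCCCc1c(C)nc(N)nc1NCCCC`, 1220 nM;
compound 3, `CCCCNc1nc(N)nc(C)c1CCCC(C)(C)O`, 1220 nM.

In an assay on HEK293 cells for agonist activity at Toll-like receptor 8 (Homo sapiens), read by spectrophotometry (a higher number here means that more compound is needed for the effect, a lower number that less compound is needed), compound 3 stands level with compound 2 at the digits shown, and together these two give the lowest numbers of the three; the two measured steps read: a 4.0-fold lower number from compound 1 to compound 2 (0.60 log units; beyond the scatter), while no change at the digits printed from compound 2 to compound 3 (within the scatter).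

Compound 4, `CCCCNc1nc(N)nc(C)c1CCC(C)(C)O`, has not yet been measured. It differs from compound 3 in one place: 1-hydroxy-1-methylethyl in place of 2-hydroxy-2-methylpropyl on a saturated chain carbon, two bonds along the chain from an aromatic carbon. The chain carrying the hydroxyl group is thus one carbon shorter.

Neither measured step bears directly on this change. The step from compound 1 to compound 2 concerns the group on the aromatic carbon, and the step from compound 2 to compound 3 adds the hydroxyl at the chain end without changing the chain length. Among the compounds with values here, with no step that shortens such a chain, the account expects compound 4 to stay close to compound 3, with a 1.3-fold higher number from compound 3 to compound 4 (0.12 log units; within the scatter), within the scatter or only somewhat beyond it.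

In this assay compound 4 is therefore estimated at 1600 nM, in a range from 500 nM to 5000 nM.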

Compound 4, half-maximal effective concentration: 3140 nM
For compound 4 the middle estimate is 2.0-fold (0.29 log units) below the measured one, within the range that was stated.
By their numbers in this assay, from the lowest: compounds 2 and 3 (each within the scatter of the next); then compounds 4 and 1 (each within the scatter of the next).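

In this assay the length of the chain carrying the hydroxyl group now shows itself at this position, where adding the hydroxyl at the chain end had moved nothing: going from 2-hydroxy-2-methylpropyl to 1-hydroxy-1-methylethyl gives a 2.6-fold higher number from compound 3 to compound 4 (0.41 log units; beyond the scatter) and the same shortened chain gives a 2.6-fold higher number from compound 2 to compound 4 (0.41 log units; beyond the scatter) against the plain alkyl chain. The advantage over the ethynyl group is lost as well, since the last step reads a 1.6-fold lower number from compound 1 to compound 4 (0.19 log units; within the scatter) and so stays inside the scatter. Nothing shown gives a reason for this shift.

The compounds shown leave open how a longer chain, such as 4-hydroxy-4-methylpentyl, would read. They also leave open whether an amine or a carboxylic acid at the chain end could stand in for the hydroxyl group.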